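Moving the furan link point in a small compound set

The source may hold more compounds than are shown below. What is called first, only, known or untested is meant among the compounds shown, and "the series" means these compounds.

Of the compounds shown here, three have been measured in a functional assay on MCF7 cells (Homo sapiens) for inhibition, with a stated time of 96 h; on this read-out lower numbers stand for stronger inhibition and higher numbers for weaker inhibition. Compound 1 `COc1cc(C(=O)c2cn(-c3cccc(C)c3)cc2-c2ccco2)cc(OC)c1OC` gives 23 nM in this assay. Compound 2 `COc1cc(C(=O)c2cn(-c3cccc(C)c3)cc2-c2ccoc2)cc(OC)c1OC` differs from compound 1 in one place: furan-3-yl in place of furan-2-yl on an aromatic carbon. In this assay compound 2 gives 21 nM. The measured step is a 1.1-fold lower number from compound 1 to compound 2 (0.04 log units; within the scatter). Compound 3 `COc1cc(C(=O)c2cn(-c3ccc(C)cc3)cc2-c2ccco2)cc(OC)c1OC` has a different core from compound 1, and the difference is 4-methylphenyl in place of 3-methylphenyl on an aromatic nitrogen. In this assay compound 3 gives 22 nM, and the step is a 1.0-fold lower number from compound 1 to compound 3 (0.02 log units; within the scatter). The three values therefore sit close together, with no separation that the method can resolve.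

Compound 4 `COc1cc(C(=O)c2cn(-c3ccc(C)cc3)cc2-c2ccoc2)cc(OC)c1OC` has not yet been measured. It stands to compound 3 as compound 2 stands to compound 1, through (furan-3-yl in place of furan-2-yl on an aromatic carbon). The surroundings of the change are not identical: in the earlier pair the altered carbon lies two ring bonds from the ring atom that bears a 3-methylphenyl group, whereas here it lies two ring bonds from the ring atom that bears a 4-methylphenyl group. It is thus the same kind of change, not the same change.

For the measured compounds named here, only one earlier example of this kind of change exists, and it stayed within the scatter, as a 1.1-fold lower number from compound 1 to compound 2 (0.04 log units; within the scatter) shows. The step from compound 3 to compound 4 is estimated as a 1.1-fold lower number from compound 3 to compound 4 (0.04 log units; within the scatter). Compound 4 is expected to give about 20 nM in this assay, with the likely range from 10 nM to 40 nM.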

Compound 4, half-maximal inhibitory concentration: 18 nM
Compound 4: middle estimate off by 1.1-fold (0.05 log units), on the high side; the measured number falls inside the stated range.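

In this assay, putting furan-3-yl in place of furan-2-yl on the core that carries the 4-methylphenyl group gives a 1.2-fold lower number from compound 3 to compound 4 (0.09 log units; within the scatter), and this step agrees with the same change on the core of compound 1: the same change on two cores in this assay, a 1.1-fold lower number (0.04 log units; within the scatter) from compound 1 to compound 2 and a 1.2-fold lower number (0.09 log units; within the scatter) from compound 3 to compound 4, 1.1-fold (0.05 log units) apart, within the scatter of two such steps. Putting 4-methylphenyl in place of 3-methylphenyl on the furan-3-yl core gives a 1.2-fold lower number from compound 2 to compound 4 (0.07 log units; within the scatter), and this step agrees with the same change on the furan-2-yl core: the same change on two cores in this assay, a 1.0-fold lower number (0.02 log units; within the scatter) from compound 1 to compound 3 and a 1.2-fold lower number (0.07 log units; within the scatter) from compound 2 to compound 4, 1.1-fold (0.05 log units) apart, within the scatter of two such steps. Each change therefore behaves alike on the two cores shown, but since every step here lies within the scatter, this shows only that neither change produces a resolvable shift on these cores; it does not show that a step of clear size would carry over from one core to another, or that the agreement would hold on any further core.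

The compounds shown leave open whether the read-out stays this flat when the furan ring gives way to a thiophene or a pyridine, or when the methyl on the phenyl group gives way to an amine or a carboxylic acid. Such larger replacements might produce steps beyond the scatter, and only steps of that kind could put the carrying over of a change to a real test.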